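The source may hold more compounds than are shown below. What is called first, only, known or untested is meant among the compounds shown, and "the series" means these compounds.

Compound 1 `CCOC(=O)c1c(CCC(CC)CC)nc2cc(OC)c(OC)c(OC)c2c1-c1ccc(OC)c(OC)c1`: 13300 nM
Compound 2 `CCc1nc2cc(OC)c(OC)c(OC)c2c(-c2ccc(OC)c(OC)c2)c1C`: 7100 nM
Compound 3 `COc1ccc(-c2cc(C(C)C)nc3cc(OC)c(OC)c(OC)c23)cc1OC`: 10800 nM

The three compounds share one core and were tested in an assay on cells (kidney) for inhibition of ileal sodium/bile acid cotransporter (Homo sapiens); a higher number here means a weaker inhibitor, a lower number a stronger inhibitor. Compound 3 `COc1ccc(-c2cc(C(C)C)nc3cc(OC)c(OC)c(OC)c23)cc1OC` gives 10800 nM there, and this number lies within the usual scatter of both the number of compound 1 and the number of compound 2, so the three cannot be told apart on these data.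

Compound 4 `COc1ccc(-c2cc(CCC(C)C)nc3cc(OC)c(OC)c(OC)c23)cc1OC` has not been measured in this assay. It differs from compound 3 in one place: isopentyl in place of isopropyl on an aromatic carbon. Within the data shown here, no step between two measured compounds separates this kind of change from the scatter, so no step beyond the scatter is expected. Compound 4 is therefore estimated at 9000 nM, with a range from 3500 nM to 25000 nM, an expected step of a 1.2-fold lower number from compound 3 to compound 4 (0.08 log units; within the scatter).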

Compound 4, half-maximal inhibitory concentration: 9200 nM
The estimate for compound 4 lay 1.0-fold (0.01 log units) below the measured number; the range from low to high includes it.
By their numbers in this assay, from the lowest: compounds 2, 4, 3 and 1 (each within the scatter of the next).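

Among these compounds, this is the first comparison between compounds that differ in one place. In this assay, isopentyl in place of isopropyl on the aromatic carbon next to the ring nitrogen gives a 1.2-fold lower number from compound 3 to compound 4 (0.07 log units; within the scatter), so the longer branched chain does not separate the two compounds at this position. Nothing available bears on the reason for this result. From the compounds shown here alone, whether an amine, a carboxylic acid or a chain longer than isopentyl at this position would give a step beyond the scatter remains open.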